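The source may hold more compounds than are shown below. What is called first, only, known or untested is meant among the compounds shown, and "the series" means these compounds.

Compound 1 `CCN(CC)c1nc(Nc2ccc(F)cc2)nc(OC(C(F)(F)F)C(F)(F)F)n1` and compound 2 `CCN(CC)c1nc(Nc2ccc3ncsc3c2)nc(OC(C(F)(F)F)C(F)(F)F)n1` share one core and differ only in the group on the nitrogen on the aromatic ring. Within the data shown here, in an assay on cells for activation of Cystic fibrosis transmembrane conductance regulator (Homo sapiens), read by fluorescence, with stated times of 10 min and 12 s (a lower number here means that less compound is needed, a higher number that more compound is needed for the effect), compound 1 gives 700 nM and compound 2 gives 50 nM; the step of a 14-fold lower number from compound 1 to compound 2 (1.15 log units; beyond the scatter) is the only measured step. On the two numbers shown, compound 1 stands at the higher one, with compound 2 as its nearest neighbour.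

Compound 3 `CCN(CC)c1nc(Nc2ccc(F)cc2)nc(OCC(F)(F)C(F)F)n1` is not yet measured. It differs from compound 1 at the oxygen on the aromatic ring: 2,2,3,3-tetrafluoropropyl in place of 2,2,2-trifluoro-1-(trifluoromethyl)ethyl on an oxygen on an aromatic ring. Among the measured compounds shown here, the measured step exchanges 1,3-benzothiazol-6-yl for 4-fluorophenyl on a nitrogen on an aromatic ring and leaves the group on the oxygen untouched, so no measured step bears on this change. With nothing to rest on, the expectation for this assay is a step of a 1.3-fold higher number from compound 1 to compound 3 (0.11 log units; within the scatter), that is none beyond the scatter, and the range is set wide. Compound 3 is accordingly estimated at 900 nM in this assay, between 300 nM and 2700 nM.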

Compound 3, half-maximal effective concentration: 4800 nM
Compound 3: the middle estimate sits 5.3-fold (0.73 log units) below what was measured; measured number outside the range, above it.
By their numbers in this assay, from the lowest: compound 2; then compound 1; then compound 3.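

The group on the oxygen on the aromatic ring turns out to matter in this assay: with the rest of the molecule held constant, 2,2,3,3-tetrafluoropropyl in place of 2,2,2-trifluoro-1-(trifluoromethyl)ethyl gives a 6.9-fold higher number from compound 1 to compound 3 (0.84 log units; beyond the scatter). Among these compounds, until now, the only measured change was on the nitrogen on the aromatic ring, so this is the first sign that the two fluorinated groups on the oxygen are not interchangeable, even though both are ring-free, uncharged and have three carbons, and the entering group differs by carrying 4 fluorine atoms rather than 6. No supporting data on why the number rises accompany this step, so it stands as an observation about this pair alone.

A single pair cannot separate the number of fluorine atoms from the arrangement of the chain, and a plain propyl chain or a 2,2,2-trifluoroethyl group on the oxygen would help to tell these apart. On these data alone, it also remains open whether the gain seen with 1,3-benzothiazol-6-yl on the nitrogen carries over when 2,2,3,3-tetrafluoropropyl sits on the oxygen.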